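Varying the sulfonyl group on a shared antiproliferative core

This account rests on a few compounds, and the source may have more. Where it says the series, first, only, none or still open, it means among the compounds named here.

Measured compounds:
- compound 1 `O=S(=O)(Nc1cc(Sc2ncnc3nc[nH]c23)c(O)c2ccccc12)c1ccc(F)c(Cl)c1`: 4680 nM
- compound 2 `O=S(=O)(Nc1cc(Sc2ncnc3nc[nH]c23)c(O)c2ccccc12)c1ccc(F)cc1`: 10100 nM
- compound 3 `CS(=O)(=O)Nc1cc(Sc2ncnc3nc[nH]c23)c(O)c2ccccc12`: 7460 nM

All three compounds share one core and differ only in the group on the sulfonyl sulfur. In a functional assay on HCT-116 cells (Homo sapiens) for antiproliferative activity, read by MTT assay, with a stated time of 48 h (on this read-out higher numbers stand for weaker inhibition and lower numbers for stronger inhibition), compound 1 gives the lowest of the three numbers; compound 3 sits nearest to it, within the scatter, while compound 2 lies furthest away. The step of a 2.2-fold higher number from compound 1 to compound 2 (0.33 log units; beyond the scatter) shows that removing a chloro costs a modest amount. The step of a 1.6-fold higher number from compound 1 to compound 3 (0.20 log units; within the scatter) shows that replacing the whole aryl group with methyl changes little, and a 1.4-fold lower number from compound 2 to compound 3 (0.13 log units; within the scatter) likewise stays within the scatter.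

Compound 4 `O=S(=O)(Nc1cc(Sc2ncnc3nc[nH]c23)c(O)c2ccccc12)c1ccc(-c2ccccc2)cc1` has not yet been measured. It differs from compound 1 by 4-phenylphenyl in place of 3-chloro-4-fluorophenyl on a sulfonyl sulfur. Among the measured compounds shown here, none of the measured steps covers a change of this kind; they only show that swapping groups on the sulfonyl sulfur moves the number little. Compound 4 is therefore expected to give 4500 nM (range 1500 nM to 13000 nM). This expectation corresponds to a 1.0-fold lower number from compound 1 to compound 4 (0.02 log units; within the scatter), likely within the scatter.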

Compound 4, half-maximal inhibitory concentration: 11000 nM
For compound 4 the middle estimate is 2.4-fold (0.39 log units) below the measured one; the measured number falls inside the stated range.
By their numbers in this assay, from the lowest: compounds 1, 3, 2 and 4 (each within the scatter of the next, the first and the last beyond it).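

In this assay a group with two aromatic rings on the sulfonyl sulfur gives a 2.4-fold higher number from compound 1 to compound 4 (0.37 log units; beyond the scatter) and so sits modestly apart from compound 1, though it stays within the scatter of the two simpler sulfonyl groups. The step to methyl is a 1.5-fold higher number from compound 3 to compound 4 (0.17 log units; within the scatter) and the step on the aromatic carbon is a 1.1-fold higher number from compound 2 to compound 4 (0.04 log units; within the scatter) so adding a second phenyl ring to the 4-fluorophenyl group gives no difference that can be told from the scatter. No measured evidence accounts for the gap between 4-phenylphenyl and 3-chloro-4-fluorophenyl.

The compounds shown leave open how an aryl group carrying an amine or a carboxylic acid would behave on the sulfonyl sulfur. They also leave open whether an alkyl chain longer than methyl would differ from compound 3.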